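The source may report more compounds than this note shows. Statements on the series, on what has been measured and on what is new or still open speak of the compounds shown alone.

In a functional assay on brain (Rattus norvegicus, strain Wistar) for inhibition (a lower number here means a stronger inhibitor, a higher number a weaker inhibitor), compound 3 (`COc1ccc(-c2c(C)[nH]c(=O)n2C2CCCCC2)cc1`) gives 20400 nM. Compound 1 (`CCCCOc1ccc(-c2c(C)[nH]c(=O)n2C2CCCCC2)cc1`) gives 13900 nM, within the usual scatter of compound 3, while compound 2 (`CCCCCOc1ccc(-c2c(C)[nH]c(=O)n2C)cc1`) gives a clearly lower number, 4500 nM. Compound 4 (`CCCCCOc1ccc(-c2c(C)[nH]c(=O)n2C2CCCCC2)cc1`) has butyl in place of hydrogen on a saturated chain carbon bound to an oxygen on an aromatic ring. The closest measured step, a 1.5-fold higher number from compound 1 to compound 3 (0.17 log units; within the scatter), also changes this chain and stays within the scatter. Compound 2 shares the pentyloxy chain of compound 4 but differs elsewhere, so it offers only a loose hint towards a lower number. No step beyond the scatter is therefore expected in this assay. The estimated step is a 1.7-fold lower number from compound 3 to compound 4 (0.23 log units; within the scatter). Compound 4 is expected at 12000 nM, within a range from 5000 nM to 25000 nM.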

Compound 4, half-maximal inhibitory concentration: 9100 nM
Beside the measured number, compound 4's estimate is 1.3-fold (0.12 log units) above it; the measured number falls inside the stated range.
By their numbers in this assay, from the lowest: compound 2; then compounds 4, 1 and 3 (each within the scatter of the next, the first and the last beyond it).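

In this assay, going from methoxy to pentyloxy now gives a change that clears the scatter, though modestly: a 2.2-fold lower number from compound 3 to compound 4 (0.35 log units; beyond the scatter). The last added carbon alone cannot be told apart, with a 1.5-fold lower number from compound 1 to compound 4 (0.18 log units; within the scatter), so the change shows only across the whole chain length. Going by these compounds alone, the first reading on the aromatic nitrogen, cyclohexyl in place of methyl, is also modest: a 2.0-fold higher number from compound 2 to compound 4 (0.31 log units; beyond the scatter).

From the compounds shown here alone, whether a longer chain such as heptyloxy, or a chain ending in an amine, would shift the number further remains open. Nothing available explains these steps.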